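Swapping a pyridine for a pyrimidine on a sulfonamide

The source may hold more compounds than are shown below. What is called first, only, known or untested is meant among the compounds shown, and "the series" means these compounds.

Three compounds share a core built around a thiourea that links a sulfonamide-bearing benzene to a quinoline carrying a trifluoromethyl group; they differ only in the group on the sulfonamide nitrogen. Compound 1 `CC(=O)NS(=O)(=O)c1ccc(N/C(S)=N\c2ccnc3cc(C(F)(F)F)ccc23)cc1` carries an acetyl there and gives 28400 nM in a functional assay on HepG2 cells (Homo sapiens) for antiproliferative activity, read by sulforhodamine B assay, with a stated time of 48 h; a lower number here means a stronger inhibitor, a higher number a weaker inhibitor. Compound 2 `N=C(N)NS(=O)(=O)c1ccc(N/C(S)=N\c2ccnc3cc(C(F)(F)F)ccc23)cc1` carries a guanidine-like group and gives 33500 nM. Compound 3 `O=S(=O)(Nc1ccccn1)c1ccc(N/C(S)=N\c2ccnc3cc(C(F)(F)F)ccc23)cc1` carries a pyridin-2-yl and gives 28000 nM. The three numbers sit close together: the step of a 1.2-fold higher number from compound 1 to compound 2 (0.07 log units; within the scatter), the step of a 1.0-fold lower number from compound 1 to compound 3 (0.01 log units; within the scatter) and the step of a 1.2-fold lower number from compound 2 to compound 3 (0.08 log units; within the scatter) all fall within the usual scatter, so none of these three groups can be told apart on these data.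

Compound 4 `O=S(=O)(Nc1ncccn1)c1ccc(N/C(S)=N\c2ccnc3cc(C(F)(F)F)ccc23)cc1` continues this series with the change (pyrimidin-2-yl in place of pyridin-2-yl on a sulfonamide nitrogen). The replacement of the acetyl by the pyridin-2-yl, from compound 1 to compound 3, moved the number hardly at all, and the other two exchanges at the same nitrogen were equally quiet. The step to the pyrimidin-2-yl is expected to behave the same way, giving no change at the digits printed from compound 3 to compound 4 (within the scatter), nothing beyond the scatter in either direction. Compound 4 is therefore estimated at 28000 nM, with a range from 14000 nM to 56000 nM.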

Compound 4, half-maximal inhibitory concentration: 42100 nM
Estimate against measurement, compound 4: 1.5-fold (0.18 log units) below; the range from low to high includes it.
By their numbers in this assay, from the lowest: compounds 3, 1, 2 and 4 (each within the scatter of the next).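

Going by these compounds alone, the second ring nitrogen of the pyrimidin-2-yl, which raises the count of hydrogen-bond acceptors in the group on the sulfonamide nitrogen, gives no step that can be read in this assay (a 1.5-fold higher number from compound 3 to compound 4 (0.18 log units; within the scatter)). The same holds against the guanidine-like group (a 1.3-fold higher number from compound 2 to compound 4 (0.10 log units; within the scatter)) and against the acetyl (a 1.5-fold higher number from compound 1 to compound 4 (0.17 log units; within the scatter)), so the four groups, with or without a ring and with one or two ring nitrogens, cannot be told apart here, and this position has so far shown no response to any of these exchanges. Nothing available on these compounds explains this flat result.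

The compounds shown leave open whether a plain hydrogen, a methyl, a longer alkyl chain or a carboxylic acid on this nitrogen would give a number beyond the scatter of these four. They also leave open what happens when the shared core changes, for example when the trifluoromethyl gives way to a chlorine, since all four compounds carry that group unchanged.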